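The source may hold more compounds than are shown below. What is called first, only, known or untested is meant among the compounds shown, and "the series" means these compounds.

Measured compounds:
compound 1, `COc1cncc(N2CCCNCC2)c1`, 1.9 nM in an assay on cell membranes for binding affinity to Neuronal acetylcholine receptor; alpha4/beta2 (Rattus norvegicus), read by radioligand binding; on this read-out lower numbers stand for stronger inhibition and higher numbers for weaker inhibition
compound 2, `COc1ccc(N2CCCNCC2)cn1`, 170 nM in this assay

Compound 2 gives the highest of the two numbers in this assay; the nearest point is compound 1, which sits at a far lower number, well beyond the scatter, so compound 2 is the weaker binder of the pair. The untested compound 3, `COc1cc(N2CCCNCC2)cnc1OC`, keeps everything of compound 2 and differs in one place: methoxy in place of hydrogen on an aromatic carbon, set ortho to the methoxy that compound 2 already carries, two atoms from the ring nitrogen and meta to the seven-atom amine ring. No change within the measured set shows this exact move, so the expectation rests on the contrast between compound 1 and compound 2 alone. A step downward beyond the scatter is expected, of the size an 8.5-fold lower number from compound 2 to compound 3 (0.93 log units; beyond the scatter), though its extent is uncertain. For compound 3 the estimated value in this assay is 20 nM, with a range from 3 nM to 130 nM.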

Compound 3, half-maximal inhibitory concentration: 170 nM
For compound 3 the middle estimate is 8.5-fold (0.93 log units) below the measured one; the whole stated range lies below it.
By their numbers in this assay, from the lowest: compound 1; then compounds 2 and 3 (each within the scatter of the next).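

The extra methoxy, ortho to a methoxy group and two atoms from the ring nitrogen, makes no difference that can be read in this assay (no change at the digits printed from compound 2 to compound 3 (within the scatter)), so compound 2 and compound 3 cannot be told apart here. This aromatic carbon therefore accepts a methoxy in place of hydrogen without any shift beyond the scatter, but compound 3 remains far from compound 1 (an 89-fold higher number from compound 1 to compound 3 (1.95 log units; beyond the scatter)). No measurement on hand explains why this position gives this result.

As far as these compounds go, it remains open whether this position would respond differently to another group, such as a fluorine, an amine or a longer ethoxy chain. From the compounds shown here alone, it is also open whether the same methoxy would be accommodated as readily on the core of compound 1.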